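The compounds below may be only part of what the source reports. "The series", "measured", "known", "first", "only" and "open" are said of these compounds alone.

Measured in an ADME assay on L02 cells (Homo sapiens) for cytotoxicity, read by MTT assay, with a stated time of 24 h; a higher number here means a weaker inhibitor, a lower number a stronger inhibitor:

Compound 1 `COc1cc(/C=C2\CN(C)C/C(=C\c3cccc([N+](=O)[O-])c3)C2=O)cc(OC)c1` gives 10800 nM.
Compound 2 `COc1cc(/C=C2\CN(C)C/C(=C\c3ccc(C#N)cc3)C2=O)cc(OC)c1` gives 14000 nM.
Compound 3 `COc1cc(/C=C2\CN(C)C/C(=C\c3cccc([N+](=O)[O-])c3)C2=O)cc(OC)c1OC` gives 13600 nM.

Compound 4 `COc1cc(/C=C2\CN(C)C/C(=C\c3ccc(C#N)cc3)C2=O)cc(OC)c1OC` has not yet been measured in this assay. It is built from compound 3 by one change, (4-cyanophenyl in place of 3-nitrophenyl on a double-bonded chain carbon bound to a double-bonded ring carbon). The same change has already been made once, from compound 1 to compound 2, and there it gave a 1.3-fold higher number from compound 1 to compound 2 (0.11 log units; within the scatter). The two cores on which the change is made are not identical: compound 3 differs from compound 1 by methoxy in place of hydrogen on an aromatic carbon, and that change gave a 1.3-fold higher number from compound 1 to compound 3 (0.10 log units; within the scatter). Since the place of the change is described in the same words for both pairs, the change from compound 3 to compound 4 counts as the same change, now on the core carrying the added methoxy.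

Within the data shown here, for compound 4 the step is expected to be a 1.2-fold higher number from compound 3 to compound 4 (0.07 log units; within the scatter), a size that rests on the earlier 1.3-fold higher number from compound 1 to compound 2 (0.11 log units; within the scatter) and on the fact that all three values so far lie within the scatter of one another. Compound 4 is therefore estimated at 16000 nM, with a likely range from 8000 nM to 32000 nM.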

Compound 4, half-maximal inhibitory concentration: 18600 nM
Compound 4: middle estimate off by 1.2-fold (0.07 log units), on the low side; the measured number falls inside the stated range.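

In this assay, putting 4-cyanophenyl in place of 3-nitrophenyl on the core with the added methoxy gives a 1.4-fold higher number from compound 3 to compound 4 (0.14 log units; within the scatter), and this step matches the earlier one on the core without that methoxy: the same change on two cores in this assay, a 1.3-fold higher number (0.11 log units; within the scatter) from compound 1 to compound 2 and a 1.4-fold higher number (0.14 log units; within the scatter) from compound 3 to compound 4, 1.1-fold (0.02 log units) apart, within the scatter of two such steps. Adding the methoxy to the 4-cyanophenyl compound gives a 1.3-fold higher number from compound 2 to compound 4 (0.12 log units; within the scatter), and the methoxy step also carries over from one core to the other: the same change on two cores in this assay, a 1.3-fold higher number (0.10 log units; within the scatter) from compound 1 to compound 3 and a 1.3-fold higher number (0.12 log units; within the scatter) from compound 2 to compound 4, 1.1-fold (0.02 log units) apart, within the scatter of two such steps. Across these four compounds, then, neither change shows any sign of depending on the core, but every step lies within the scatter, so this agreement does not show that either change has a real effect on the number or that the same would hold on other cores.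

From the compounds shown here alone, what stays open is whether a clearly different group at the same place, such as an amine or a carboxylic acid in place of the nitrile, would give a step beyond the scatter. If it did, it would remain to be seen whether that larger step also carries over between the two cores.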